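Second trifluoromethyl on the ether analogue of the thioether pair

The compounds below may be only part of what the source reports. "The series", "measured", "known", "first", "only" and "open" are said of these compounds alone.

The series pairs a hydroxy-amide linker with an aryl sulfide or aryl ether and a pentafluorosulfanyl-bearing anilide. Compound 1 `CC(O)(CSc1cccc(C(F)(F)F)c1)C(=O)Nc1cccc(S(F)(F)(F)(F)F)c1` is the thioether with a single trifluoromethyl on the sulfur-linked ring; in a functional assay on VCaP cells (Homo sapiens) for antiproliferative activity, read by propidium iodide staining, with a stated time of 96 h (on this read-out lower numbers stand for stronger inhibition and higher numbers for weaker inhibition), compound 1 gives 20200 nM. Compound 2 `CC(O)(CSc1cc(C(F)(F)F)cc(C(F)(F)F)c1)C(=O)Nc1cccc(S(F)(F)(F)(F)F)c1` differs from it by trifluoromethyl in place of hydrogen on an aromatic carbon, and in this assay compound 2 gives 4000 nM, so that a 5.1-fold lower number from compound 1 to compound 2 (0.70 log units; beyond the scatter).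

Compound 3 `CC(O)(COc1cccc(C(F)(F)F)c1)C(=O)Nc1ccc(S(F)(F)(F)(F)F)cc1` is built on a different core; the difference between the core of compound 1 and the core of compound 3 is not broken down here. In this assay compound 3 gives 24700 nM. Its number and that of compound 1 lie within the scatter of each other, while the number of compound 2 sits lower than that of compound 3 by a margin beyond the scatter.

Compound 4 `CC(O)(COc1cc(C(F)(F)F)cc(C(F)(F)F)c1)C(=O)Nc1ccc(S(F)(F)(F)(F)F)cc1` differs from compound 3 by trifluoromethyl in place of hydrogen on an aromatic carbon. Among the compounds with values here, this is the same change, in a place described in the same words, as the one between compound 1 and compound 2; it occurs twice in the set. Within the data shown here, the step from compound 3 to compound 4 in this assay is expected to be of similar size, a 4.9-fold lower number from compound 3 to compound 4 (0.69 log units; beyond the scatter), because a 5.1-fold lower number from compound 1 to compound 2 (0.70 log units; beyond the scatter) is the only precedent available, and the core differs, so the expectation is held loosely. Compound 4 is therefore estimated to give 5000 nM, within a range of 2000 nM to 13000 nM.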

Compound 4, half-maximal inhibitory concentration: 2600 nM
Estimate against measurement, compound 4: 1.9-fold (0.28 log units) above; low and high end bracket the measured number.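

In this assay, trifluoromethyl in place of hydrogen on an aromatic carbon gives a 9.5-fold lower number from compound 3 to compound 4 (0.98 log units; beyond the scatter), so the change that lowered the number on the core of compound 1 does the same on the core of compound 3. Set side by side, the two steps run in the same direction and cannot be told apart in size: the same change on two cores in this assay, a 5.1-fold lower number (0.70 log units; beyond the scatter) from compound 1 to compound 2 and a 9.5-fold lower number (0.98 log units; beyond the scatter) from compound 3 to compound 4, 1.9-fold (0.27 log units) apart, within the scatter of two such steps

This supports carrying the change between these two cores in this assay, but it rests on one pair per core, says nothing about any third core, and does not establish that the step would keep its size elsewhere in the series.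

As far as these compounds go, it remains open whether a smaller or differently built group, such as chlorine or a nitrile, in place of the added trifluoromethyl would give a step of similar size. From the compounds shown here alone, the part played by the hydroxy group of the linker also remains open, and a pair with a methoxy group or a hydrogen at that carbon, on either core, would address it.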